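The compounds below may be only part of what the source reports. "The series", "measured", "known", "first", "only" and "open" are said of these compounds alone.

In an ADME assay on microsomes from liver (Rattus norvegicus) for metabolic stability (on this read-out higher numbers stand for fast clearance and lower numbers for slow clearance), compound 2 `CNc1nc(NC2(C#N)CCCCC2)nc(-n2cncn2)n1` gives 52 mL/min/kg. Among the measured compounds shown here, compound 1 `CNc1nc(NC2(C#N)CCCC(C)C2)nc(-n2cncn2)n1` gives 96 mL/min/kg, a number within the usual scatter of the one for compound 2. Compound 3 `CNc1nc(NC2(C#N)CCCCC2)nc(N2CCCC2)n1` gives > 276 mL/min/kg, which is a limit of the assay and not a number.

Compound 4 `CNc1nc(NC2(C#N)CCCCC2C)nc(-n2cncn2)n1` keeps the rest of compound 2 but has methyl in place of hydrogen on a saturated ring carbon, next to the ring atom that bears a cyano group: methyl in place of hydrogen on a saturated ring carbon.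

Two measured steps can be weighed. The closer one is a 1.8-fold lower number from compound 1 to compound 2 (0.27 log units; within the scatter). It is the same kind of change run the other way, with the methyl leaving a different carbon of the same ring. The other is an at least 5.3-fold higher number from compound 2 to compound 3 (0.72 log units; beyond the scatter), which lies beyond the scatter but comes from pyrrolidin-1-yl in place of 1H-1,2,4-triazol-1-yl on an aromatic carbon, so it says little about a methyl on the saturated ring.

Read in reverse, the closer step points to a small rise, though it is only a weak guide since it lies within the scatter. The expected step is a 1.5-fold higher number from compound 2 to compound 4 (0.19 log units; within the scatter), a small move toward faster clearance. For compound 4 the estimated value is 80 mL/min/kg, with an expected range from 40 mL/min/kg to 170 mL/min/kg.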

Compound 4, clearance in the Rattus norvegicus assay: 86 mL/min/kg
Estimate against measurement, compound 4: 1.1-fold (0.03 log units) below; the range from low to high includes it.
By their numbers in the Rattus norvegicus assay, from the lowest: compounds 2, 4 and 1 (each within the scatter of the next). At a limit, above all of these: compound 3.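

Among the compounds shown here, in the Rattus norvegicus assay a methyl on this saturated ring carbon, next to the ring atom that bears a cyano group, gives a 1.7-fold higher number from compound 2 to compound 4 (0.22 log units; within the scatter), so this first look at the position shows no step that can be told apart from repeat measurements. Compound 4 gives 86 mL/min/kg and compound 1, with its methyl on a different carbon of the same ring, gives 96 mL/min/kg, two values within the scatter of each other, so in this pair the choice of carbon makes no readable difference. The same methyl on this position also goes with a modest rise in a physicochemical assay for solubility, at pH 7.4 (a lower number here means a less soluble compound, a higher number a more soluble compound), where compound 2 gives 11 ug/mL and compound 4 gives 25 ug/mL, seen here in one pair of compounds only: the measured solubility of compound 2, 11 ug/mL, and of compound 4, 25 ug/mL, a 2.3-fold higher number (0.36 log units; beyond the scatter).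

The compounds shown carry only hydrogen or methyl on this carbon, so how an ethyl chain, a hydroxyl group or an amine there would read in the Rattus norvegicus assay and in the physicochemical assay stays open. On these data alone, in the Rattus norvegicus assay compound 3 gives > 276 mL/min/kg, a limit of the assay and not a number, so whether a methyl on this carbon would matter with pyrrolidin-1-yl in the molecule also stays open.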